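The compounds below may be only part of what the source reports. "The series", "measured", "known", "first", "only" and "open" are said of these compounds alone.

Measured in a functional assay on A549 cells (Homo sapiens) for antiproliferative activity, read by MTT assay, with a stated time of 72 h; a higher number here means a weaker inhibitor, a lower number a stronger inhibitor:
compound 1 `NC1=NC2(CCOCC2)N(OCCCOc2ccc(Cl)c(Cl)c2)C(N)=N1` gives 790 nM;
compound 2 `NC1=NC2(CCSCC2)N(OCCCOc2ccc(Cl)cc2)C(N)=N1` gives 580 nM;
compound 3 `NC1=NC2(CCOCC2)N(OCCCOc2cccc(Br)c2)C(N)=N1` gives 160 nM.

Among these three numbers compound 2 stands second highest, within the scatter of compound 1 and well above compound 3. Compound 4 `NC1=NC2(CCSCC2)N(OCCCOc2ccc(Cl)c(Cl)c2)C(N)=N1` differs from compound 2 in one place: chloro in place of hydrogen on an aromatic carbon, that is, 4-chlorophenyl to 3,4-dichlorophenyl. For the measured compounds named here, one measured step bears on this: a 4.9-fold lower number from compound 1 to compound 3 (0.69 log units; beyond the scatter), where the 3,4-dichlorophenyl compound is the weaker of the pair. Compound 1, carrying that same 3,4-dichlorophenyl, and compound 2 lie within the scatter of each other, so adding the second chloro is expected to change little. For compound 4 the expected step is a 1.3-fold higher number from compound 2 to compound 4 (0.11 log units; within the scatter), giving an estimate of 750 nM, between 320 nM and 1700 nM.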

Compound 4, half-maximal inhibitory concentration: 1 nM
Compound 4: the middle estimate sits 750-fold (2.88 log units) above what was measured; the measured number lies below the stated range.
By their numbers in this assay, from the lowest: compound 4; then compound 3; then compounds 2 and 1 (each within the scatter of the next).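

Adding one chloro to the 4-chlorophenyl group gives a 580-fold lower number from compound 2 to compound 4 (2.76 log units; beyond the scatter), so a single heavy atom at this position of the ring can decide most of the activity. That group alone does not settle it: compound 4 gives 1 nM and compound 1, with the same 3,4-dichlorophenyl but oxygen in place of sulfur in the core, gives 790 nM. No measurement available here explains the jump.

From the compounds shown here alone, whether a methyl or methoxy group at this position would act like the chloro remains open. So does the size of this step in the oxygen core.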